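A Second Chloro Group Added to Compound 2

A few compounds are considered here, and "the series" means these few. Any claim that something is new, unique, unknown or untested is made for them only; others in the source may bear on it.

Three compounds sharing a common core were measured in an assay on isolated protein for inhibition of Dihydrofolate reductase (Mus musculus); a lower number here means a less potent compound, a higher number a more potent compound, by a factor of ten per unit of this negative logarithm. Compound 1 `CC1(C)N=C(N)N=C(N)N1c1ccc(SCC(=O)Nc2ccc(S(=O)(=O)F)cc2)cc1` gives 7.52. Compound 3 `CC1(C)N=C(N)N=C(N)N1c1ccc(SCC(=O)Nc2ccc(S(=O)(=O)F)cc2)c(Cl)c1` carries chloro in place of hydrogen on an aromatic carbon and gives 7.42, so that the step of a number 0.10 log units lower from compound 1 to compound 3 (within the scatter). Compound 2 `CC1(C)N=C(N)N=C(N)N1c1ccc(OCc2cccc(S(=O)(=O)F)c2)c(Cl)c1` gives 7.72; how its core differs from that of compound 1 is not broken down here, and its value, like those of compounds 1 and 3, lies within the usual scatter of the other two.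

Compound 4 `CC1(C)N=C(N)N=C(N)N1c1ccc(OCc2cccc(S(=O)(=O)F)c2Cl)c(Cl)c1` has not yet been measured. Relative to compound 2 it carries chloro in place of hydrogen on an aromatic carbon. This is the same kind of change as that from compound 1 to compound 3, though not the same: there the entering chloro sat ortho to a large group and meta to a large group, whereas in compound 4 it sits ortho to a fluorosulfonyl group and ortho to a large group. Because the earlier step of a number 0.10 log units lower from compound 1 to compound 3 (within the scatter) stayed within the scatter, a step of similar size is expected for compound 4. In this assay the expected step is a number 0.12 log units lower from compound 2 to compound 4 (within the scatter). Compound 4 is accordingly estimated at 7.6, with a likely range from 7.2 to 8.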

Compound 4, logarithm of the reciprocal of the active concentration, log(1/C): 7.49
Compound 4: the middle estimate sits 0.11 log units above what was measured; the measured number falls inside the stated range.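

In this assay, the new step is a number 0.23 log units lower from compound 2 to compound 4 (within the scatter). Set beside the earlier step, the same change on the other core gives a result that cannot be told apart from it: the same change on two cores in this assay, a number 0.10 log units lower (within the scatter) from compound 1 to compound 3 and a number 0.23 log units lower (within the scatter) from compound 2 to compound 4, 0.13 log units apart, within the scatter of two such steps Across these two cores, then, chloro in place of hydrogen on an aromatic carbon left the number within the scatter each time, which is consistent with the change carrying over, but two small steps show neither a shared size nor a rule for any further core in this series.

The compounds shown leave open whether a fluoro, a methyl or an amine on the same aromatic carbon, ortho to a fluorosulfonyl group and ortho to a large group, would also stay within the scatter. They also leave open whether chloro would behave in the same way on a core with a longer chain in its linker.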